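The compounds below may be only part of what the source reports. "The series", "measured", "known", "first", "only" and "open" are said of these compounds alone.

Within the data shown here, in a functional assay on A2780 cells (Homo sapiens) for antiproliferative activity, read by MTT assay, with a stated time of 48 h (on this read-out higher numbers stand for weaker inhibition and lower numbers for stronger inhibition), compound 2 (`CNCC(=O)Nc1cc(OC)ccc1C(=O)c1ccc(OC)c2c1C=CC(C)(C)O2`) gives 1590 nM and sits within the scatter of compound 1 (`COc1ccc(C(=O)c2ccc(OC)c3c2C=CC(C)(C)O3)c(NC(=O)CBr)c1`), which gives 2150 nM as the only other number so far. Compound 3 (`CCNCC(=O)Nc1cc(OC)ccc1C(=O)c1ccc(OC)c2c1C=CC(C)(C)O2`) has methyl in place of hydrogen on a saturated chain carbon bound to an amine nitrogen. Among the measured compounds shown here, the only measured step (a 1.4-fold lower number from compound 1 to compound 2 (0.13 log units; within the scatter)) is a different change and stays within the scatter, so it gives no ground for expecting a large shift. In this assay the expected step is none beyond the scatter (a 1.1-fold higher number from compound 2 to compound 3 (0.03 log units; within the scatter)). Compound 3 is estimated at 1700 nM with an expected range of 750 nM to 3800 nM for repeat measurements.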

Compound 3, half-maximal inhibitory concentration: 4090 nM
Compound 3: middle estimate off by 2.4-fold (0.38 log units), on the low side; measured number outside the range, above it.
By their numbers in this assay, from the lowest: compounds 2, 1 and 3 (each within the scatter of the next, the first and the last beyond it).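

In this assay, among these compounds, methyl in place of hydrogen on a saturated chain carbon bound to an amine nitrogen gives a 2.6-fold higher number from compound 2 to compound 3 (0.41 log units; beyond the scatter), the only step so far beyond the scatter, so methylamino to ethylamino is not a neutral change at this position. Measured against the bromo compound, ethylamino gives a 1.9-fold higher number from compound 1 to compound 3 (0.28 log units; within the scatter), so that replacement shows no readable change. No measured evidence offers an explanation for the step.

From the compounds shown here alone, whether inhibition weakens further with a longer chain such as propylamino remains open. Going by these compounds, the effects of a primary amino group, dimethylamino or a cyclic amine such as morpholine at this position also remain open.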